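Chloro to bromo exchange at the (4-chlorophenyl)amino group

The compounds below may be only part of what the source reports. "The series", "measured", "known", "first", "only" and "open" are said of these compounds alone.

Within the data shown here, compound 3 `Cc1ccc(NC(=S)Nc2ccc(S(=O)(=O)Nc3ccc(Cl)cc3)cc2)cc1` gives 100 mg/kg in a functional assay on the whole organism with Mus musculus as the target, in the maximal electroshock model, with a stated time of 0.5 h (a lower number here means that less compound is needed, a higher number that more compound is needed for the effect), the lowest of the three numbers measured so far. Compound 1 `O=C(N/N=C/c1ccccc1Cl)Nc1ccc(Br)cc1` gives 300 mg/kg and compound 2 `CN(C)c1ccc(/C=N/NC(=O)Nc2ccc(Br)cc2)cc1` gives 300 mg/kg; both stand beyond the scatter from compound 3, and both rest on a different core. Compound 4 `Cc1ccc(NC(=S)Nc2ccc(S(=O)(=O)Nc3ccc(Br)cc3)cc2)cc1` is the untested analogue; it differs from compound 3 by bromo in place of chloro on an aromatic carbon. Among the measured compounds shown here, no measured pair in this set shows a halogen exchange of this kind, so its effect cannot be read from the data. An exchange of one halogen for another on the same aromatic carbon is expected to leave this assay about where it stands, with no step beyond the scatter: the expected step of no change at the digits printed from compound 3 to compound 4 (within the scatter) is flat. Compound 4 is therefore estimated at 100 mg/kg, within 50 mg/kg to 200 mg/kg.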

Compound 4, minimum effective dose: 100 mg/kg
Compound 4: the middle estimate sits on the measured number at the digits printed; the measured number falls inside the stated range.
By their numbers in this assay, from the lowest: compounds 3 and 4 (each within the scatter of the next); then compounds 1 and 2 (each within the scatter of the next).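

In this assay, among these compounds, the exchange of 4-chlorophenyl for 4-bromophenyl gives no change at the digits printed from compound 3 to compound 4 (within the scatter) and is the only pair that differs in one place. At this aromatic carbon, on the core of compound 3, either halogen therefore serves equally; compounds 1 and 2, on a different core, could not show this. Nothing measured here accounts for the flat step. Open, from the compounds shown here alone, is whether hydrogen, an amine or a carboxylic acid at this carbon would keep the reading within the scatter.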